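Amine exchange at the ring nitrogen neighbour: compound 2 to 4

The source may hold more compounds than are shown below. What is called first, only, known or untested is meant among the compounds shown, and "the series" means these compounds.

Measured in a functional assay on cells (Lymphocyte), read by a luciferase reporter and ATP content, with a stated time of 48 h, tested at 5 uM; on this read-out higher numbers stand for a weaker effect at the one concentration tested and lower numbers for a stronger effect:
compound 1 `CCCCCCCCCCc1c(C)c(N(C)C)nc(C)c1O` gives 87%
compound 2 `CCCCCCCCCCCCCCCCc1nc(N2CCC2)c(C)c(C)c1O` gives 92%
compound 3 `CCCCCCCCCCCCCCCCc1c(C)c(N2CCC2)nc(C)c1O` gives 98%

Compound 2 holds the second highest of the three numbers in this assay; compound 1 is the nearest, lower but within the scatter, and compound 3 the furthest, higher but also within the scatter. Within the data shown here, no pair of measured compounds differs in one place only, so no single-point step is known from the data. Compound 4 `CCCCCCCCCCCCCCCCc1nc(N(C)C)c(C)c(C)c1O` differs from compound 2 as follows: dimethylamino in place of azetidin-1-yl on an aromatic carbon. Because compound 2 gives 92% and the other two measured values sit within the scatter of it, the step from compound 2 to compound 4 is expected to be none beyond the scatter, no change at the digits printed from compound 2 to compound 4 (within the scatter). Compound 4 is estimated at 92%, with a range of 80% to 100% in this assay.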

Compound 4, a percentage reported as activity, at one concentration (the size of the read-out at that concentration, not a potency): 100%
Compound 4: middle estimate off by 8 percentage points, on the low side, and the stated range covers the measured number.
By their numbers in this assay, from the lowest: compounds 1, 2, 3 and 4 (each within the scatter of the next, the first and the last beyond it).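

In this assay, among these compounds, exchanging azetidin-1-yl for dimethylamino on the aromatic carbon next to the ring nitrogen gives a number 8 percentage points higher from compound 2 to compound 4 (within the scatter) and provides the only single-point step so far. At this position, the four-membered ring and the open dimethylamino group therefore read alike at the one concentration tested. No measured evidence bears on this step.

Still open, on these data alone, is how a larger cyclic amine such as piperidine or morpholine would read on this aromatic carbon. As far as these compounds go, it is also open whether a primary amine here would move the number beyond the scatter.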